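From three ring hydroxyls to one: an expected shift

This account rests on a few compounds, and the source may have more. Where it says the series, first, only, none or still open, it means among the compounds named here.

In a functional assay on HeLa cells (Homo sapiens) for cytotoxicity, read by MTT assay (on this read-out lower numbers stand for stronger inhibition and higher numbers for weaker inhibition), compound 1 `COc1cc(O)c(CC=C(C)C)c(O)c1C(=O)/C=C/c1cc(O)c(O)c(O)c1` gives 30300 nM, the highest of the two numbers in hand. Compound 2 `COc1cc(O)cc(O)c1C(=O)/C=C/c1ccc(O)cc1` gives 5200 nM, a gap that lies beyond the usual scatter. Compound 3 `COc1cc(O)c(CC=C(C)C)c(O)c1C(=O)/C=C/c1cccc(O)c1` has not yet been measured; it differs from compound 1 by 3-hydroxyphenyl in place of 3,4,5-trihydroxyphenyl on a double-bonded chain carbon bound to a double-bonded chain carbon. Going by the values given here, no measured pair tracks this exact change. Because compound 2 gives 5200 nM while also lacking the 3,4,5-trihydroxyphenyl, a lower number is expected for compound 3, estimated at 10000 nM with a range from 3000 nM to 30000 nM. The expected step is a 3.0-fold lower number from compound 1 to compound 3 (0.48 log units; beyond the scatter).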

Compound 3, half-maximal inhibitory concentration: 4800 nM
Compound 3: middle estimate off by 2.1-fold (0.32 log units), on the high side; low and high end bracket the measured number.
By their numbers in this assay, from the lowest: compounds 3 and 2 (each within the scatter of the next); then compound 1.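

In this assay, the change of 3,4,5-trihydroxyphenyl to 3-hydroxyphenyl gives a 6.3-fold lower number from compound 1 to compound 3 (0.80 log units; beyond the scatter), with the rest of the core held fixed. Going by these compounds alone, this is the first matched reading at this position, on a double-bonded chain carbon bound to a double-bonded chain carbon, and it shows that inhibition here responds to the substitution of this ring. Nothing in hand explains the shift.

The compounds shown leave open which of the lost hydroxyls accounts for the step, and whether the remaining one matters. From the compounds shown here alone, how an unsubstituted phenyl or a 3-aminophenyl would read on this core also remains open.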